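A few compounds are considered here, and "the series" means these few. Any claim that something is new, unique, unknown or untested is made for them only; others in the source may bear on it.

Of the compounds shown here, three built on one shared core have been tested in a functional assay on 786-0 cells (Homo sapiens) for inhibition, read by sulforhodamine B assay, with a stated time of 48 h, tested at 10 uM; on this read-out higher numbers stand for more inhibition at the one concentration tested (going by the name of the read-out) and lower numbers for less inhibition. Compound 1 `Brc1cn2ccnc2c(-c2ccc3ncn(C4CCCCC4)c3c2)n1` carries a bromo group and gives 10%. Compound 2 `O=Cc1ccc(-c2cn3ccnc3c(-c3ccc4ncn(C5CCCCC5)c4c3)n2)cc1` carries a 4-formylphenyl group in that place and gives 46.7%, the highest of the three numbers. Compound 3 `Clc1ccc(-c2cn3ccnc3c(-c3ccc4ncn(C5CCCCC5)c4c3)n2)cc1` carries a 4-chlorophenyl group and gives 12.1%. Between them, a number 36.7 percentage points higher from compound 1 to compound 2 (beyond the scatter), while a number 2.1 percentage points higher from compound 1 to compound 3 (within the scatter), and a number 34.6 percentage points lower from compound 2 to compound 3 (beyond the scatter).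

Compound 4 `c1csc(-c2cn3ccnc3c(-c3ccc4ncn(C5CCCCC5)c4c3)n2)c1` has not yet been measured. It differs from compound 2 in one place: thiophen-2-yl in place of 4-formylphenyl on an aromatic carbon. Among the measured compounds shown here, two measured steps bear on this. The step that installed the formyl-bearing ring was large, and the step that exchanged the formyl for chloro was equally large in the other direction, so the two compounds without a formyl group, compound 1 and compound 3, both sit low. Because compound 3 without a formyl group gives 12.1%, a large fall is expected for compound 4 as well. Compound 4 is therefore estimated at 18%, within a range from 5% to 40%. This expected change amounts to a number 28.7 percentage points lower from compound 2 to compound 4 (beyond the scatter).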

Compound 4, a percentage reported as inhibition, at one concentration (the size of the read-out at that concentration, not a potency): 4.1%
Estimate against measurement, compound 4: 13.9 percentage points above; the measured number lies below the stated range.
By their numbers in this assay, from the lowest: compounds 4, 1 and 3 (each within the scatter of the next); then compound 2.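

In this assay the change at this aromatic carbon gives a number 42.6 percentage points lower from compound 2 to compound 4 (beyond the scatter) and so adds a five-membered ring to the groups that do not match compound 2, while a number 8 percentage points lower from compound 3 to compound 4 (within the scatter) and a number 5.9 percentage points lower from compound 1 to compound 4 (within the scatter) show no difference from the other two compounds beyond the scatter. Among these four compounds, bromo, 4-chlorophenyl and thiophen-2-yl cannot be told apart, so an aromatic ring at this place does not by itself go with a higher number, and only compound 2, with its 4-formylphenyl group, stands apart. Nothing shown here explains why compound 2 alone stands apart.

From the compounds shown here alone, it remains open whether the formyl group itself is what counts, which a phenyl ring bearing a carboxylic acid, an amine or a hydroxymethyl group at that place could help to test. Going by these compounds, it is also open whether a formyl group on the thiophene ring would give a number like that of compound 2.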